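Three Measured Analogues and a Carboxyphenyl Replacement

A few compounds are considered here, and "the series" means these few. Any claim that something is new, unique, unknown or untested is made for them only; others in the source may bear on it.

Compound 1, `CCCCCCCCc1ccc(OCC(=O)Cn2nnc(C)n2)cc1`, gives 27 nM in an assay on microsomes from brain for inhibition of Fatty-acid amide hydrolase 1 (Rattus norvegicus), read by fluorescence and HPLC, with a stated time of 60 min; a lower number here means a stronger inhibitor, a higher number a weaker inhibitor.
Compound 2, `CCCCCCCCc1ccc(OCC(=O)Cn2nnc(-c3ccccc3Cl)n2)cc1`, gives 32 nM in this assay.
Compound 3, `CCCCCCCCc1ccc(OCC(=O)Cn2nnc(CCC(=O)O)n2)cc1`, gives 30 nM in this assay.

Compound 2 holds the highest of the three numbers in this assay, but only narrowly: its nearest neighbour is compound 3, reached by a 1.1-fold lower number from compound 2 to compound 3 (0.03 log units; within the scatter), and its furthest is compound 1, separated by a 1.2-fold higher number from compound 1 to compound 2 (0.07 log units; within the scatter). Both gaps sit inside the usual scatter, so the three compounds cannot be ordered on these data.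

Compound 4, `CCCCCCCCc1ccc(OCC(=O)Cn2nnc(-c3cccc(C(=O)O)c3)n2)cc1`, differs from compound 2 in a single place: 3-carboxyphenyl in place of 2-chlorophenyl on an aromatic carbon.

Within the data shown here, three measured steps bear on this change, all at the same position of the shared core. The step of a 1.2-fold higher number from compound 1 to compound 2 (0.07 log units; within the scatter) swaps a small group for an aryl ring, a 1.1-fold higher number from compound 1 to compound 3 (0.05 log units; within the scatter) introduces a carboxylic acid on a chain, and a 1.1-fold lower number from compound 2 to compound 3 (0.03 log units; within the scatter) exchanges the aryl ring for that acid chain. Among the measured compounds shown here, every one of them stays within the scatter, so neither an aryl ring nor a carboxylic acid at this position has moved the number so far. Compound 4 combines both features in one group, and the expected outcome is therefore a step of a 1.1-fold lower number from compound 2 to compound 4 (0.03 log units; within the scatter) that lies within the scatter. For compound 4 the estimated value in this assay is 30 nM, with an expected range from 15 nM to 65 nM.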

Compound 4, half-maximal inhibitory concentration: 36 nM
Compound 4: the middle estimate sits 1.2-fold (0.08 log units) below what was measured; measured number inside the range.
By their numbers in this assay, from the lowest: compounds 1, 3, 2 and 4 (each within the scatter of the next).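

Compound 4 carries an aryl ring and a carboxylic acid in one group, and in this assay exchanging 2-chlorophenyl for 3-carboxyphenyl gives a 1.1-fold higher number from compound 2 to compound 4 (0.05 log units; within the scatter), so the acid can sit on a ring as well as on a chain without the number leaving the scatter. The step from the acid chain reads the same, with a 1.2-fold higher number from compound 3 to compound 4 (0.08 log units; within the scatter), and so does the step from the small methyl group, with a 1.3-fold higher number from compound 1 to compound 4 (0.12 log units; within the scatter). A group of 9 heavy atoms bearing a hydrogen-bond donor reads no differently here from methyl, and the four compounds still cannot be ranked. Nothing available explains why the number stays so flat across these groups.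

Going by these compounds, all four groups at this position are either carbon-only or carry a carboxylic acid, so it remains open whether an amine, a hydroxyl or an amide there would also leave the number unchanged. All four compounds also share the long chain on the phenyl ring, which leaves open whether a shorter chain in its place would make this position matter more.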